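Benzyl for Phenyl on a Weakly Cytotoxic Amide Series

The source may hold more compounds than are shown below. What is called first, only, known or untested is meant among the compounds shown, and "the series" means these compounds.

Compound 1, `Cc1ccc2nc(C)n(NC(=O)/C(C#N)=C/c3ccc([N+](=O)[O-])cc3)c(=O)c2c1`: 12000 nM
Compound 2, `Cc1ccc2nc(C)n(-n3c(N)cc(N)c(C#N)c3=O)c(=O)c2c1`: 10000 nM
Compound 3, `Cc1ccc2nc(C)n(NC(=O)c3sc(=S)n(-c4ccccc4)c3N)c(=O)c2c1`: 13000 nM

All three compounds share one core and were tested in a functional assay on MCF7 cells (Homo sapiens) for cytotoxicity, read by MTT assay, with a stated time of 3 days; a higher number here means a weaker inhibitor, a lower number a stronger inhibitor. Compound 3 carries the highest of the three numbers, yet its gaps to compound 1 and to compound 2 both lie within the scatter, so no order among the three can be drawn; all are weak.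

Compound 4, `Cc1ccc2nc(C)n(NC(=O)c3sc(=S)n(Cc4ccccc4)c3N)c(=O)c2c1`, differs from compound 3 in one place: benzyl in place of phenyl on an aromatic nitrogen. For the measured compounds named here, no measured pair in this set shows what such a change does, so any expectation rests on compound 3 alone. The step from compound 3 to compound 4 is expected to be a 1.1-fold lower number from compound 3 to compound 4 (0.03 log units; within the scatter), that is, nothing beyond the scatter. Compound 4 is therefore estimated at 12000 nM, with a range from 5000 nM to 30000 nM.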

Compound 4, half-maximal inhibitory concentration: 10000 nM
For compound 4 the middle estimate is 1.2-fold (0.08 log units) above the measured one; low and high end bracket the measured number.
By their numbers in this assay, from the lowest: compounds 2, 4, 1 and 3 (each within the scatter of the next).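

Benzyl in place of phenyl on the aromatic nitrogen gives a 1.3-fold lower number from compound 3 to compound 4 (0.11 log units; within the scatter) in this assay. For the compounds shown here, this is the first reading at this position, and it shows that placing benzyl there leaves the number inside the scatter, with both compounds still weak. No measured finding accounts for this result.

On these data alone, whether a longer chain such as phenethyl on this nitrogen would give a step beyond the scatter remains open. The same question stands for a chain ending in an amine or a carboxylic acid.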